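The source may report more compounds than this note shows. Statements on the series, on what has been measured and on what is new or still open speak of the compounds shown alone.

- compound 1 (`COc1cc(/C=C2\CN(S(=O)(=O)c3ccc(F)cc3)C/C(=C\c3cc(OC)cc(OC)c3)C2=O)cc(OC)c1`) gives (8100 nM)
- compound 2 (`CC(=O)Nc1ccc(S(=O)(=O)N2C/C(=C\c3ccc(C#N)cc3)C(=O)/C(=C/c3ccc(C#N)cc3)C2)cc1`) gives (4880 nM)
- compound 3 (`COc1cc(/C=C2\CN(S(=O)(=O)c3ccc(NC(C)=O)cc3)C/C(=C\c3cc(OC)c(OC)c(OC)c3)C2=O)cc(OC)c1OC`) gives (3890 nM)

In a functional assay on HepG2 cells (Homo sapiens) for cytotoxicity, read by MTT assay, with a stated time of 24 h (a higher number here means a weaker inhibitor, a lower number a stronger inhibitor), compound 1 lies within the scatter of compound 2 and beyond the scatter above compound 3. Compound 4 (`COc1cc(/C=C2\CN(S(=O)(=O)c3ccc(F)cc3)C/C(=C\c3cc(OC)c(OC)c(OC)c3)C2=O)cc(OC)c1`) differs from compound 1 by one change (methoxy in place of hydrogen on an aromatic carbon), methoxy in place of hydrogen on an aromatic carbon, which turns 3,5-dimethoxyphenyl to 3,4,5-trimethoxyphenyl. Going by the values given here, no measured pair isolates this change. Compound 3 carries 3,4,5-trimethoxyphenyl and gives (3890 nM), but it also differs from compound 1 elsewhere, so it is only a loose guide. A small downward step, none beyond the scatter, is expected in this assay, estimated as (a 1.4-fold lower number from compound 1 to compound 4 (0.13 log units; within the scatter)). Compound 4 is estimated at (6000 nM), with an expected range from 2800 nM to 12000 nM inclusive.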

Compound 4, half-maximal inhibitory concentration: 3890 nM
The estimate for compound 4 lay 1.5-fold (0.19 log units) above the measured number, and the stated range covers the measured number.
By their numbers in this assay, from the lowest: compounds 3, 4, 2 and 1 (each within the scatter of the next, the first and the last beyond it).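

In this assay, going by these compounds alone, the methoxy entering ortho to two methoxy groups and para to a large group gives a 2.1-fold lower number from compound 1 to compound 4 (0.32 log units; beyond the scatter), a modest step beyond the scatter and the first one-place change in this set. It shows that turning 3,5-dimethoxyphenyl to 3,4,5-trimethoxyphenyl on one side alone lowers the number in this assay. Nothing available explains this step. The compounds shown leave open whether a hydroxyl, an amine or an ethoxy group at this position would do the same. They also leave open whether the same change on the remaining 3,5-dimethoxyphenyl group would lower the number further.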